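The source may report more compounds than this note shows. Statements on the series, on what has been measured and on what is new or still open speak of the compounds shown alone.

Going by the values given here, in a functional assay on K562 cells (Homo sapiens) for cytotoxicity, read by MTT assay, with a stated time of 72 h (a lower number here means a stronger inhibitor, a higher number a weaker inhibitor), compound 1 `C=C1C(=O)[C@@]23C(=O)OC[C@]4(C(=O)CCC(C)(C)[C@H]4C=O)[C@@H]2CC[C@@H]1[C@H]3O` gives 2180 nM, the lower of the two numbers so far. Compound 2 `C=C1C(=O)[C@@]23C(=O)OC[C@]4([C@@H](OC(C)=O)CCC(C)(C)[C@H]4C=O)[C@@H]2CC[C@@H]1[C@H]3O` gives 9560 nM, and that gap lies beyond the usual scatter. Compound 3 `C=C1C(=O)[C@@]23C(=O)OC[C@]4(C(=O)CCC(C)(C)[C@H]4C=O)[C@@H]2CC[C@@H]1[C@H]3OC(C)=O` keeps the core of compound 1 and changes one group: acetyl in place of hydrogen on an oxygen on a saturated carbon, with acetyl in place of hydrogen on an oxygen on a saturated carbon, so hydroxy becomes acetoxy. Among the compounds with values here, no measured pair shows this change alone, so the forecast is loose. The expected step in this assay, a 1.2-fold lower number from compound 1 to compound 3 (0.08 log units; within the scatter), stays within the scatter, with no clear direction. For compound 3 the estimated value is 1800 nM, with an expected range of 600 nM to 6000 nM.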

Compound 3, half-maximal inhibitory concentration: 1390 nM
Compound 3: the middle estimate sits 1.3-fold (0.11 log units) above what was measured; the range from low to high includes it.
By their numbers in this assay, from the lowest: compounds 3 and 1 (each within the scatter of the next); then compound 2.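

Putting an acetyl on this oxygen turns hydroxy into acetoxy and gives a 1.6-fold lower number from compound 1 to compound 3 (0.20 log units; within the scatter) in this assay, so the free hydroxy hydrogen is not needed to keep this level of cytotoxicity in K562 cells. The acetyl group's extra atoms are also accepted here without a change beyond the scatter. No independent measurement is available to explain this result. Still open, from the compounds shown here alone, is whether a longer ester such as benzoate, a methyl ether or an amine at this place would behave the same way.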